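A few compounds are considered here, and "the series" means these few. Any claim that something is new, unique, unknown or untested is made for them only; others in the source may bear on it.

Of the compounds shown here, three built on one shared core have been measured in an assay on isolated protein for binding affinity to 5-hydroxytryptamine receptor 1B (Homo sapiens); a lower number here means a stronger inhibitor, a higher number a weaker inhibitor. Compound 1 `COc1cc2c(cc1N1C[C@@H](C)N(C)[C@@H](C)C1)N(C(=O)c1ccc(-c3cccc(C)n3)c3ccccc13)CC2` gives 3.16 nM, compound 2 `COc1cc2c(cc1N1CCN(C)CC1)N(C(=O)Nc1cccc(Cl)c1Cl)CC2` gives 3.98 nM, and compound 3 `COc1cc2c(cc1N1C[C@@H](C)N(C)[C@@H](C)C1)N(C(=O)Nc1cccc(Cl)c1Cl)CC2` gives 7.94 nM, which is the highest of the three numbers. Going by the values given here, the only measured pair that differs in a single place is the one where a 2.0-fold higher number from compound 2 to compound 3 (0.30 log units; within the scatter), and that step stays within the scatter.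

Compound 4 `COc1cc2c(cc1N1C[C@@H](C)N(C)[C@@H](C)C1)N(C(=O)c1cccc(Cl)c1Cl)CC2` differs from compound 3 in one place: 2,3-dichlorophenyl in place of (2,3-dichlorophenyl)amino on a carbonyl carbon. Among the compounds with values here, no measured step covers this exchange directly. Compound 1 also carries an aromatic ring bound straight to its carbonyl carbon, and its number in this assay stands lower than that of compound 3, but its ring system is a different one, so the comparison is loose.

The exchange is expected to move the number little, perhaps a modest drop, so compound 4 is estimated at 5 nM with a range from 1.5 nM to 16 nM. The expected step of a 1.6-fold lower number from compound 3 to compound 4 (0.20 log units; within the scatter) is therefore estimated to lie within the scatter.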

Compound 4, inhibition constant: 12.6 nM
The estimate for compound 4 lay 2.5-fold (0.40 log units) below the measured number; low and high end bracket the measured number.
By their numbers in this assay, from the lowest: compounds 1, 2, 3 and 4 (each within the scatter of the next, the first and the last beyond it).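

On the carbonyl carbon, 2,3-dichlorophenyl in place of (2,3-dichlorophenyl)amino gives, in this assay, a 1.6-fold higher number from compound 3 to compound 4 (0.20 log units; within the scatter). The exchange removes the amino nitrogen and its hydrogen, the one hydrogen-bond donor in the leaving group, yet the two compounds cannot be told apart in this measurement, so with this shared core that donor is not needed for binding in the nanomolar range. No supporting measurement is available to explain this result.

From the compounds shown here alone, it remains open whether the same exchange would be just as quiet with 4-methylpiperazin-1-yl on the aromatic carbon. Going by these compounds, it is also open how a methylene group or an oxygen atom would behave in the place of the amino nitrogen, since either would keep the dichlorophenyl ring one atom further from the carbonyl carbon.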